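Swapping the chain tail on a shared flavone-type scaffold

A few compounds are considered here, and "the series" means these few. Any claim that something is new, unique, unknown or untested is made for them only; others in the source may bear on it.

Compound 1 `COc1cc(OC)c2c(=O)cc(-c3ccc(OCCN4CCCC4=O)cc3)oc2c1` and compound 2 `COc1cc(OC)c2c(=O)cc(-c3ccc(OCCCN)cc3)oc2c1` share one core and differ only in the group at the end of the side chain. In a functional assay (Homo sapiens) for antiproliferative activity, read by resazurin assay, with a stated time of 48 h, tested at 5 uM (a higher number here means a stronger effect of the compound at the concentration tested, a lower number a weaker effect), compound 1 gives 7%, and compound 2 gives 22%. The step of a number 15 percentage points higher from compound 1 to compound 2 (beyond the scatter) is the only one measured, and it leaves compound 2 standing highest of the two numbers shown. Compound 3 `COc1cc(OC)c2c(=O)cc(-c3ccc(NCCN4CCCC4)cc3)oc2c1` has not been measured; it differs from compound 2 by (2-(pyrrolidin-1-yl)ethyl)amino in place of 3-aminopropoxy on an aromatic carbon. The measured step from compound 1 to compound 2 bears on this change only in part, since it too altered the nitrogen-bearing tail of the chain, and its size was modest. He therefore expects a step of a number 8 percentage points higher from compound 2 to compound 3 (within the scatter) for compound 3, upward but small. Compound 3 is estimated at 30%, between 10% and 55%.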

Compound 3, a percentage reported as inhibition, at one concentration (the size of the read-out at that concentration, not a potency): 21%
Estimate against measurement, compound 3: 9 percentage points above; the measured number falls inside the stated range.
By their numbers in this assay, from the lowest: compound 1; then compounds 3 and 2 (each within the scatter of the next).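

The change at this aromatic carbon, (2-(pyrrolidin-1-yl)ethyl)amino in place of 3-aminopropoxy, gives a number 1 percentage points lower from compound 2 to compound 3 (within the scatter), so compounds 2 and 3 cannot be told apart in this assay even though the entering group adds a five-membered non-aromatic ring and a second nitrogen. Set against the 2-(2-oxopyrrolidin-1-yl)ethoxy group of compound 1, the same group gives a number 14 percentage points higher from compound 1 to compound 3 (beyond the scatter), which shows that two differently built amine-bearing groups at this position both stand clear of compound 1. Nothing available explains why these two groups read alike.

Because the link atom and the chain end changed together between compounds 2 and 3, their separate contributions remain unresolved. Also open, as far as these compounds go, is whether a piperidine or morpholine ring at the chain end, or a longer chain, would move the read-out beyond the scatter.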